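The source may report more compounds than this note shows. Statements on the series, on what has been measured and on what is new or still open speak of the compounds shown alone.

In an ADME assay on S9 fraction from liver (Rattus norvegicus) for metabolic stability, read by LC-MS, using NADPH, with a stated time of 30 min (on this read-out lower numbers stand for a less stable compound and higher numbers for a more stable compound), compound 1 `CCCCCCCCc1ccc(OCC(=O)Cn2nnc(-c3ccc(C(=O)OC)cc3)n2)cc1` gives 64%. Compound 2 `CCCCCCCCc1ccc(OCC(=O)Cn2nnc(-c3ccc(C(=O)O)cc3)n2)cc1` carries hydrogen in place of methyl on an oxygen next to a carbonyl group, and in this assay compound 2 returns only a limit of the assay, < 5%. That single measured step, a number at least 59 percentage points lower from compound 1 to compound 2 (beyond the scatter), ends at the limit of < 5% in this assay, at which 1 of the 3 values shown sits. Compound 3 `CCCCCCCCc1ccc(OCC(=O)Cn2nnnc2-c2ccccc2)cc1` gives 36% in this assay, the lower of the two numbers shown, standing beyond the scatter below compound 1. Compound 4 `CCCCCCCCc1ccc(OCC(=O)Cn2nnnc2C(=O)OC)cc1` differs from compound 3 by methoxycarbonyl in place of phenyl on an aromatic carbon. Among the measured compounds shown here, no measured step matches this change: the one step on record swaps methyl for hydrogen on an oxygen, whereas here a phenyl leaves and a methoxycarbonyl enters on an aromatic carbon of the core. The direction is therefore open, and only a modest shift is expected, so compound 4 is expected to move by a number 6 percentage points lower from compound 3 to compound 4 (within the scatter) relative to compound 3. For compound 4 the estimate in this assay is 30%, with a range from 5% to 60%.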

Compound 4, percent of the compound remaining: 38%
For compound 4 the middle estimate is 8 percentage points below the measured one; low and high end bracket the measured number.
By their numbers in this assay, from the lowest: compounds 3 and 4 (each within the scatter of the next); then compound 1. At a limit, below all of these: compound 2.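

In this assay, methoxycarbonyl in place of phenyl on this aromatic carbon gives a number 2 percentage points higher from compound 3 to compound 4 (within the scatter). Among the compounds shown here, at this place, then, a group with no ring and 2 hydrogen-bond acceptors and a six-membered aromatic ring of carbon only cannot be told apart on this read-out, a reading that the one earlier step, a change in a different place, could not give. No measurement shown gives a reason for this result.

On these data alone, it remains open whether an amine, a carboxylic acid or a longer chain on this same carbon would also give a number close to these two. For the compounds shown here, it is also open whether hydrogen in place of methyl on the methoxycarbonyl of compound 4 would bring as large a step as the one seen between compound 1 and compound 2.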